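The source may hold more compounds than are shown below. What is called first, only, known or untested is meant among the compounds shown, and "the series" means these compounds.

Measured compounds: compound 1, `COc1ccc2nc(-c3cccc(O)c3)c(=O)n(CC(=O)O)c2c1`, gives 8.5% in a functional assay, with a stated time of 240 min, tested at 100 uM; on this read-out lower numbers stand for a weaker effect and higher numbers for a stronger effect at the one concentration tested; compound 2, `COc1ccc2nc(/C=C/c3ccc(O)c(OC)c3)c(=O)n(CC(=O)O)c2c1`, gives 83.5%; compound 3, `COc1ccc2c(c1)nc(/C=C/c1ccc(O)cc1)c(=O)n2CC(=O)O`, gives 51.8%.

Compound 3 stands second highest of the three numbers. Its nearest neighbour is compound 2, whose number lies higher by a margin beyond the scatter; compound 1 lies far lower, also beyond the scatter.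

Compound 4, `COc1ccc2c(c1)nc(/C=C/c1ccc(O)c(OC)c1)c(=O)n2CC(=O)O`, differs from compound 3 in one place: methoxy in place of hydrogen on an aromatic carbon. Compound 2 carries the same 4-hydroxy-3-methoxyphenyl group and gives 83.5%, so an upward step of moderate size, beyond the scatter, is expected from compound 3 to compound 4. The estimated step is a number 20.2 percentage points higher from compound 3 to compound 4 (beyond the scatter).

Compound 4 is therefore expected to give about 72% in this assay, within a range from 55% to 88%.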

Compound 4, a percentage reported as activity, at one concentration (the size of the read-out at that concentration, not a potency): 74.9%
Compound 4: the middle estimate sits 2.9 percentage points below what was measured; measured number inside the range.
By their numbers in this assay, from the lowest: compound 1; then compound 3; then compounds 4 and 2 (each within the scatter of the next).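

In this assay, the change from 4-hydroxyphenyl to 4-hydroxy-3-methoxyphenyl gives a number 23.1 percentage points higher from compound 3 to compound 4 (beyond the scatter). This is the first reading among these compounds that isolates a single change, here methoxy in place of hydrogen ortho to a hydroxy group. Nothing available explains the step.

The compounds shown leave open whether this step is particular to methoxy, or whether an ethoxy group, a fluorine atom or a second hydroxy group on the same carbon would give a similar one. They also leave open whether the methoxy step persists without the neighbouring hydroxy group.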